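Methoxy for chloro on the pendant aryl of compound 2

A few compounds are considered here, and "the series" means these few. Any claim that something is new, unique, unknown or untested is made for them only; others in the source may bear on it.

Three amides on the shared core have numbers in a functional assay on PC-3 cells (Homo sapiens) for cytotoxicity, read by MTT assay, with a stated time of 72 h; on this read-out higher numbers stand for weaker inhibition and lower numbers for stronger inhibition. Compound 1 `O=C(Nc1nc2ccc(F)cc2s1)c1cn(-c2ccccc2)nc1-c1ccc(Cl)cc1` gives 5790 nM; compound 2 `O=C(Nc1nc2ccc(Cl)cc2s1)c1cn(-c2ccccc2)nc1-c1ccc(Cl)cc1` gives 3230 nM; compound 3 `COc1ccc2nc(NC(=O)c3cn(-c4ccccc4)nc3-c3ccc(Cl)cc3)sc2c1` gives 29300 nM. Compound 2 has the lowest number of the three, though compound 1 lies within the scatter of it (a 1.8-fold lower number from compound 1 to compound 2 (0.25 log units; within the scatter)), and only compound 3 stands apart (a 9.1-fold higher number from compound 2 to compound 3 (0.96 log units; beyond the scatter)).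

Compound 4 `COc1ccc(-c2nn(-c3ccccc3)cc2C(=O)Nc2nc3ccc(Cl)cc3s2)cc1` differs from compound 2 by methoxy in place of chloro on an aromatic carbon, that is, on the aryl attached to the pyrazole rather than on the benzothiazole. The measured steps that bear on this swap are on the other ring: a 5.1-fold higher number from compound 1 to compound 3 (0.70 log units; beyond the scatter) and a 9.1-fold higher number from compound 2 to compound 3 (0.96 log units; beyond the scatter), both raising the number. Among the measured compounds shown here, no step on the aryl of the pyrazole has been measured, so carry-over is uncertain. For the measured compounds named here, a modest rise in this assay is expected, smaller than that seen at the benzothiazole because of a 9.1-fold higher number from compound 2 to compound 3 (0.96 log units; beyond the scatter) being the only direct precedent. Compound 4 is estimated at 8000 nM, within 2500 nM to 25000 nM, a step of a 2.5-fold higher number from compound 2 to compound 4 (0.39 log units; beyond the scatter).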

Compound 4, half-maximal inhibitory concentration: 6510 nM
Estimate against measurement, compound 4: 1.2-fold (0.09 log units) above; the range from low to high includes it.
By their numbers in this assay, from the lowest: compounds 2, 1 and 4 (each within the scatter of the next); then compound 3.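

In this assay, 4-methoxyphenyl in place of 4-chlorophenyl gives a 2.0-fold higher number from compound 2 to compound 4 (0.30 log units; within the scatter), so at this position the exchange cannot be told apart from repeat-measurement noise. The same exchange of chloro for methoxy at the other substituted site on the shared core gives a 9.1-fold higher number from compound 2 to compound 3 (0.96 log units; beyond the scatter), which lies beyond the scatter, so the outcome of this swap in the series depends on where it is made. No measurement in hand accounts for this difference between the two sites.

What the compounds shown leave open is whether this position stays as permissive for groups of a different kind, such as an amine, a carboxylic acid or a longer chain like butoxy. Also open, from the compounds shown here alone, is whether a hydroxy group or a morpholine ring here would give a step beyond the scatter in either direction.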